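Phenyl for Methyl on the Ester: Predicting Compound 4

This account rests on a few compounds, and the source may have more. Where it says the series, first, only, none or still open, it means among the compounds named here.

Of the compounds shown here, three sharing a carbonyl-ester arrangement have been tested in a functional assay on HBL-100 cells (Homo sapiens) for inhibition, read by sulforhodamine B assay, with a stated time of 48 h; a higher number here means a weaker inhibitor of growth, a lower number a stronger inhibitor of growth. Compound 1 `CC(=O)OC/C(=C\C1CCCCC1)C(=O)c1ccccc1` gives 21000 nM. Compound 2 `O=C(OC/C(=C\C1CCCCC1)C(=O)c1ccccc1)c1ccccc1` gives 23000 nM. Compound 3 `CC(=O)OC/C(=C/c1ccc(Cl)cc1Cl)C(=O)c1ccccc1` gives 23000 nM, level with compound 2 at the digits shown. The change from compound 1 to compound 2 is phenyl in place of methyl on a carbonyl carbon, and it made a 1.1-fold higher number from compound 1 to compound 2 (0.04 log units; within the scatter). The difference between the core of compound 1 and the core of compound 3 is not broken down here.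

Compound 4 `O=C(OC/C(=C/c1ccc(Cl)cc1Cl)C(=O)c1ccccc1)c1ccccc1` has not yet been measured. It differs from compound 3 by phenyl in place of methyl on a carbonyl carbon; the place is described in the same words as for the earlier pair, so this is the same change. Because the earlier step, a 1.1-fold higher number from compound 1 to compound 2 (0.04 log units; within the scatter), lay within the scatter, the step from compound 3 to compound 4 is also expected to be small, about a 1.1-fold higher number from compound 3 to compound 4 (0.04 log units; within the scatter). Compound 4 is therefore estimated to give 25000 nM in this assay, with a range from 12000 nM to 50000 nM.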

Compound 4, concentration for 50% growth inhibition: 26000 nM
Compound 4: middle estimate off by 1.0-fold (0.02 log units), on the low side; the range from low to high includes it.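

In this assay, putting phenyl in place of methyl on a carbonyl carbon of the core of compound 3 gave a 1.1-fold higher number from compound 3 to compound 4 (0.05 log units; within the scatter). Set beside the earlier case, the same change looks alike on the two cores: the same change on two cores in this assay, a 1.1-fold higher number (0.04 log units; within the scatter) from compound 1 to compound 2 and a 1.1-fold higher number (0.05 log units; within the scatter) from compound 3 to compound 4, 1.0-fold (0.01 log units) apart, within the scatter of two such steps

This shows that the swap left the reading of this assay essentially unmoved on both cores, and that a small step seen on one core was a fair guide to the step on the other. It does not show that a change with a real effect would carry across these cores in the same way, since neither step rises above the scatter of the measurement.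

The compounds shown hold only methyl and phenyl at this place, leaving open what a longer chain such as butyl, or an amine on the same carbonyl carbon, would do on either core. On these data alone, whether any such group would move the number beyond the scatter, and whether that move would match on both cores, also stays open.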